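The compounds below may be only part of what the source reports. "The series", "measured", "known", "first", "only" and "open" are said of these compounds alone.

Measured so far, in a functional assay on SK-OV-3 cells (Homo sapiens) for cytotoxicity, read by sulforhodamine B assay, with a stated time of 48 h; on this read-out higher numbers stand for weaker inhibition of growth and lower numbers for stronger inhibition of growth:
compound 1 `ClCc1ccccc1Cn1cnc2c(Cl)nc(Cl)nc21` gives 1820 nM
compound 2 `ClCc1ccccc1Cn1cnc2c(Cl)ncnc21` gives 4170 nM
compound 3 `ClCc1ccccc1Cn1cnc2ncnc(Cl)c21` gives 7580 nM

Compound 2 and compound 3 share the same atoms joined differently; the difference between the two cores is not broken down here. From compound 2 to compound 1 the change is chloro in place of hydrogen on an aromatic carbon, and it brought a 2.3-fold lower number from compound 2 to compound 1 (0.36 log units; beyond the scatter).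

Compound 4 `ClCc1ccccc1Cn1cnc2nc(Cl)nc(Cl)c21` has not yet been measured. It differs from compound 3 by chloro in place of hydrogen on an aromatic carbon, the same change seen once before, from compound 2 to compound 1. Resting on that single earlier step, a step of about the same size is expected from compound 3 to compound 4, namely a 2.3-fold lower number from compound 3 to compound 4 (0.36 log units; beyond the scatter). Compound 4 is therefore estimated at 3300 nM in this assay, with a likely range from 1500 nM to 7500 nM.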

Compound 4, concentration for 50% growth inhibition: 5880 nM
The estimate for compound 4 lay 1.8-fold (0.25 log units) below the measured number, within the range that was stated.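

In this assay, chloro in place of hydrogen on the core of compound 3 gave a 1.3-fold lower number from compound 3 to compound 4 (0.11 log units; within the scatter), a step too small to tell apart from no change. Set beside the earlier step, this one does not clearly differ: the same change on two cores in this assay, a 2.3-fold lower number (0.36 log units; beyond the scatter) from compound 2 to compound 1 and a 1.3-fold lower number (0.11 log units; within the scatter) from compound 3 to compound 4, 1.8-fold (0.25 log units) apart, within the scatter of two such steps. The change therefore shows no measurable dependence on the core, but two steps, only one of them beyond the scatter, cannot show that it carries over reliably from one core to another.

The compounds shown leave open what other groups would do on the aromatic carbon between two ring nitrogen atoms. An amine or a methoxy group there could give a larger step or a smaller one.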